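Moving the Nitrile on Compound 3

The source may hold more compounds than are shown below. What is called first, only, known or untested is meant among the compounds shown, and "the series" means these compounds.

Values in a functional assay on A549 cells (Homo sapiens) for antiproliferative activity, read by MTT assay, with a stated time of 72 h; on this read-out lower numbers stand for stronger inhibition and higher numbers for weaker inhibition:
- Compound 1 `COc1cc2c(Nc3ccc(C#N)cc3)ncnc2cc1OCCCN1CCCCC1CCO`: > 100000 nM, a limit of the assay and not a number
- Compound 2 `COc1cc2c(Nc3ccc(C#N)cc3)ncnc2cc1OCCCN1CCC(N(C)C)CC1`: 42400 nM
- Compound 3 `COc1cc2c(Nc3ccc(C#N)cc3)ncnc2cc1OCCCN1CCN(C)CC1`: 48800 nM

Among the compounds with values here, compound 3, at 48800 nM, cannot be told apart from the only other compound with a true number, since a 1.2-fold higher number from compound 2 to compound 3 (0.06 log units; within the scatter) lies within the scatter. Compound 4 `COc1cc2c(Nc3ccccc3C#N)ncnc2cc1OCCCN1CCN(C)CC1` keeps the same atoms but joins them differently: 2-cyanophenyl in place of 4-cyanophenyl on a nitrogen on an aromatic ring. In words, 2-cyanophenyl stands in place of 4-cyanophenyl on a nitrogen on an aromatic ring.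

Within the data shown here, no measured step touches this group. All three change the group at the end of the chain: an at least 2.3-fold lower number from compound 1 to compound 2 (0.37 log units; beyond the scatter), an at least 2.0-fold lower number from compound 1 to compound 3 (0.31 log units; beyond the scatter) and a 1.2-fold higher number from compound 2 to compound 3 (0.06 log units; within the scatter). The first two are modest and rest on a limit, and the third is within the scatter. They therefore give only a rough sense of size, and no direction for the new change. In this assay, no shift beyond the scatter is expected, though this is uncertain. The expected step is a 1.0-fold lower number from compound 3 to compound 4 (0.01 log units; within the scatter). For compound 4 the estimated value is 48000 nM, with an expected range from 16000 nM to 100000 nM.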

Compound 4, half-maximal inhibitory concentration: 23400 nM
For compound 4 the middle estimate is 2.1-fold (0.31 log units) above the measured one; low and high end bracket the measured number.
By their numbers in this assay, from the lowest: compounds 4, 2 and 3 (each within the scatter of the next, the first and the last beyond it). At a limit, above all of these: compound 1.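

In this assay, where the nitrile sits on the ring matters: a 2.1-fold lower number from compound 3 to compound 4 (0.32 log units; beyond the scatter). Within the data shown here, this is the first measured change away from the group at the end of the chain, and it shows that rearranging the same atoms, with 2-cyanophenyl replacing 4-cyanophenyl, can move the number beyond the scatter. The shift is modest and rests on this single pair, so it shows only that this part of the molecule can affect the read-out, not how general the effect is.

Nothing measured here explains the shift. Going by these compounds, it remains open whether another group, such as 2-chlorophenyl or 2-methoxyphenyl, would do the same in place of 2-cyanophenyl, and whether 2-cyanophenyl would give a similar step alongside the 4-(dimethylamino)piperidin-1-yl group at the end of the chain.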